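The source may hold more compounds than are shown below. What is called first, only, known or untested is meant among the compounds shown, and "the series" means these compounds.

Compound 1 `CC(=O)OCCCS(=O)(=O)c1ccc(S(N)(=O)=O)s1` and compound 2 `NS(=O)(=O)c1ccc(S(=O)(=O)CCCCO)s1` share one core and differ in a single place: hydroxymethyl in place of acetoxy on a saturated chain carbon, three bonds along the chain from a sulfonyl sulfur In a physicochemical assay for solubility, at pH 7.4 (on this read-out higher numbers stand for higher solubility and lower numbers for lower solubility), compound 1 gives 920 ug/mL, and compound 2 gives 9900 ug/mL; the step of an 11-fold higher number from compound 1 to compound 2 (1.03 log units; beyond the scatter). Compound 3 `CC(=O)OCCCCc1ccc(S(N)(=O)=O)cc1` rests on another core; the difference between the two cores is not broken down here. In this assay compound 3 gives 800 ug/mL, a number within the scatter of that for compound 1 and well under that for compound 2. Compound 4 `NS(=O)(=O)c1ccc(CCCCCO)cc1` has not yet been measured. Within the data shown here, its difference from compound 3 is: hydroxymethyl in place of acetoxy on a saturated chain carbon, four bonds along the chain from an aromatic carbon This is the same kind of change as the one from compound 1 to compound 2, though what differs around the place is that the group now sits four bonds along the chain from an aromatic carbon rather than three bonds along the chain from a sulfonyl sulfur. For compound 4 the expected step is an 8.8-fold higher number from compound 3 to compound 4 (0.94 log units; beyond the scatter), judged beside an 11-fold higher number from compound 1 to compound 2 (1.03 log units; beyond the scatter) and resting on that single measured instance of the change. Compound 4 is therefore estimated at 7000 ug/mL, between 2500 ug/mL and 15000 ug/mL.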

Compound 4, solubility: 2600 ug/mL
Beside the measured number, compound 4's estimate is 2.7-fold (0.43 log units) above it; measured number inside the range.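

In this assay the change from acetoxy to hydroxymethyl gives a 3.3-fold higher number from compound 3 to compound 4 (0.51 log units; beyond the scatter) as a modest step, against an 11-fold higher number from compound 1 to compound 2 (1.03 log units; beyond the scatter) as a large one, so the direction carries from one core to the other and both steps lie beyond the scatter. The size does not carry over whole, and these two instances cannot show whether the core or the place sets that size, since the group sits four bonds along the chain from an aromatic carbon in one and three bonds along the chain from a sulfonyl sulfur in the other. Nothing shown gives a reason for either step or for the difference in their size.

The compounds shown leave open what happens on either core when an amine or a carboxylic acid takes the place of hydroxymethyl. They also leave open whether a longer chain bearing the hydroxymethyl keeps the direction of the step.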